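The compounds below may be only part of what the source reports. "The series", "measured", "known", "first", "only" and "open" are said of these compounds alone.

In an ADME assay on WI-38 cells (Homo sapiens) for cytotoxicity, read by MTT assay, with a stated time of 72 h (on this read-out higher numbers stand for weaker inhibition and lower numbers for stronger inhibition), compound 1 `O=C(CCc1cccc2c1B(O)OC2)Nc1ccc(Cl)cc1` gives > 100000 nM, which is a limit of the assay and not a number. Compound 2 `Cc1ccc(NC(=O)CCc2cccc3c2B(O)OC3)cc1` gives > 100000 nM, also a limit. Going by the values given here, compound 3 `CC(C)(C)c1ccc(NC(=O)CCc2cccc3c2B(O)OC3)cc1` gives 55000 nM, the only true number among the three. Compound 4 `COc1ccc(NC(=O)CCc2cccc3c2B(O)OC3)cc1` differs from it by one change: methoxy in place of tert-butyl on an aromatic carbon. Among the compounds with values here, two measured steps bear on this, an at least 1.8-fold lower number from compound 1 to compound 3 (0.25 log units; that floor lies within the scatter) and an at least 1.8-fold lower number from compound 2 to compound 3 (0.25 log units; that floor lies within the scatter), and the limits hide their true size. Read in reverse, they point to a modest move towards a higher number. The expected step is a 1.8-fold higher number from compound 3 to compound 4 (0.26 log units; within the scatter), and the result may well be only a limit. For compound 4 the estimated value is 100000 nM, with an expected range of 60000 nM to 200000 nM.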

Compound 4, half-maximal inhibitory concentration: > 100000 nM
Compound 4: a limit, no number (the forecaster's own chance of this, stated with the estimate: 70%); the middle value sits exactly at the limit.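

Putting methoxy in place of tert-butyl on this aromatic carbon gives an at least 1.8-fold higher number from compound 3 to compound 4 (0.25 log units; that floor lies within the scatter) and so a floor, not a true size. Methoxy, the only group here carrying an oxygen, joins chloro and methyl at the limit, which leaves tert-butyl as the only one of the four groups with a true number. The steps from compound 1 and compound 2 to compound 4 cannot be read, because both ends of each sit at the same limit: the limit of > 100000 nM in this assay, at which 3 of the 4 values shown sit.

From the compounds shown here alone, whether compound 1, compound 2 and compound 4 truly differ stays open. So does how an amine or a carboxylic acid would read at this place.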